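The source may report more compounds than this note shows. Statements on the series, on what has been measured and on what is new or still open speak of the compounds shown alone.

In a functional assay on SMMC-7721 cells (Homo sapiens) for cytotoxicity, read by MTT assay, with a stated time of 48 h (a higher number here means a weaker inhibitor, a lower number a stronger inhibitor), compound 1 (`CCN(CC)Cc1cc(Cl)cc2c(=O)cc(-c3ccccc3Cl)oc12`) gives 810 nM and compound 2 (`O=c1cc(-c2ccccc2Cl)oc2c(CN3CCCCC3)cc(Cl)cc12`) gives 3400 nM as the higher of the two numbers, which makes compound 2 the weaker inhibitor so far. Among the measured compounds shown here, the one measured step that bears on the next change is a 4.2-fold higher number from compound 1 to compound 2 (0.62 log units; beyond the scatter) and it shows that swapping the group at this place can move the number beyond the scatter. Compound 3 (`O=c1cc(-c2ccccc2Cl)oc2c(Cn3ccnc3)cc(Cl)cc12`) is still unmeasured, and it differs from compound 2 in a single group (1H-imidazol-1-yl in place of piperidin-1-yl on a saturated chain carbon bound to an aromatic carbon). The earlier step did not involve 1H-imidazol-1-yl, so it offers a size to keep in mind but no direction. The expected change (a 1.1-fold lower number from compound 2 to compound 3 (0.05 log units; within the scatter)) is therefore small, although a modest step either way remains possible. For compound 3 the estimated value is 3000 nM (expected range 800 nM to 11000 nM).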

Compound 3, half-maximal inhibitory concentration: 1070 nM
Compound 3: middle estimate off by 2.8-fold (0.45 log units), on the high side, and the stated range covers the measured number.
By their numbers in this assay, from the lowest: compounds 1 and 3 (each within the scatter of the next); then compound 2.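

In this assay the change to 1H-imidazol-1-yl gives a 3.2-fold lower number from compound 2 to compound 3 (0.50 log units; beyond the scatter), so a second swap on this saturated chain carbon also moves the number beyond the scatter, this time downward. Set against diethylamino, the same group gives a 1.3-fold higher number from compound 1 to compound 3 (0.12 log units; within the scatter), so among these three groups only piperidin-1-yl stands apart, and having a ring at this place does not by itself set the number, since compound 2 and compound 3 both carry one. No measurement of any property of these groups is available to account for these steps.

As far as these compounds go, whether the aromatic ring of 1H-imidazol-1-yl matters stays open, and a 1H-pyrazol-1-yl or morpholin-4-yl group would bear on that. Also open, from the compounds shown here alone, is how the number responds to a longer chain between this group and the shared core.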